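A few compounds are considered here, and "the series" means these few. Any claim that something is new, unique, unknown or untested is made for them only; others in the source may bear on it.

Compounds measured so far:
- compound 1 `OC[C@H]1O[C@@H](CNCc2ccccc2)[C@H](O)[C@@H](O)[C@@H]1O`: 1330000 nM
- compound 2 `OC[C@H]1O[C@@H](CNCc2ccc(Cl)c(Cl)c2)[C@H](O)[C@@H](O)[C@@H]1O`: 221000 nM
- compound 3 `COc1ccc(CNC[C@@H]2O[C@H](CO)[C@@H](O)[C@H](O)[C@H]2O)c(OC)c1`: 160000 nM

These values come from an assay on isolated protein for inhibition of lysosomal alpha-glucosidase (Rattus norvegicus), with stated times of 15 min and 60 min; on this read-out lower numbers stand for stronger inhibition and higher numbers for weaker inhibition. Among the three, compound 1 has the highest number, so it is the weakest inhibitor of the set; compound 2 and compound 3 both give lower numbers, and both gaps lie beyond the usual scatter. Compound 4 `OC[C@H]1O[C@@H](CNCc2cccs2)[C@H](O)[C@@H](O)[C@@H]1O` has not been measured yet. It differs from compound 1 in one place: thiophen-2-yl in place of phenyl on a saturated chain carbon bound to an amine nitrogen. Within the data shown here, no measured pair shows this exact change, so the expectation rests on compound 1 alone. A step from compound 1 to compound 4 of a 1.5-fold lower number from compound 1 to compound 4 (0.17 log units; within the scatter) is expected in this assay, essentially within the scatter. Compound 4 is therefore estimated at 900000 nM, with a range from 300000 nM to 3000000 nM.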

Compound 4, half-maximal inhibitory concentration: 324000 nM
Estimate against measurement, compound 4: 2.8-fold (0.44 log units) above, and the stated range covers the measured number.
By their numbers in this assay, from the lowest: compounds 3, 2 and 4 (each within the scatter of the next, the first and the last beyond it); then compound 1.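

In this assay, putting thiophen-2-yl in place of phenyl on the saturated chain carbon bound to an amine nitrogen gives a 4.1-fold lower number from compound 1 to compound 4 (0.61 log units; beyond the scatter). This shows that inhibition at this position responds to the aromatic ring itself: a five-membered ring with one sulfur gives a different number from the six-membered carbon ring. The data shown offer no explanation for this step. Still open, as far as these compounds go, is whether furan-2-yl or a pyridine ring would give a similar step. This single pair also cannot say whether thiophen-3-yl would match thiophen-2-yl.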